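From phenyl to 4-fluorophenyl on a short-lived compound

The source may report more compounds than this note shows. Statements on the series, on what has been measured and on what is new or still open speak of the compounds shown alone.

Values measured in an ADME assay on a cell-free system (plasma, Mus musculus) for metabolic stability, read by LC-MS, tested at 2 uM; on this read-out higher numbers stand for a longer-lived compound and lower numbers for a shorter-lived compound:
compound 1 `O=C(NCCCCc1ccccc1)n1cc(-c2ccccc2)oc1=O`: < 0.0834 h
compound 2 `CCCCCNC(=O)n1cc(-c2ccccc2)oc1=O`: > 2 h

Compound 1 gives < 0.0834 h in this assay, and this is a limit of the assay, not a number. Compound 2 gives > 2 h, which is also a limit. Among the measured compounds shown here, the one measured step is an at least 23-fold higher number from compound 1 to compound 2 (1.37 log units; beyond the scatter). It is large, and it alters the chain, with methyl in place of phenyl on a saturated chain carbon.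

Compound 3 `O=C(NCCCCc1ccccc1)n1cc(-c2ccc(F)cc2)oc1=O` keeps the chain of compound 1 and differs elsewhere: fluoro in place of hydrogen on an aromatic carbon. In words, this is fluoro in place of hydrogen on an aromatic carbon, phenyl to 4-fluorophenyl. For the measured compounds named here, no measured step covers a change at this place, so the large step on the chain gives no size for it and bears on it only loosely. With that chain unchanged, compound 3 is expected to stay close to compound 1 in this assay, quite possibly at the same limit. The expected change is a step that the limit leaves unreadable from compound 1 to compound 3, which would lie within the scatter. For compound 3 the estimated half-life is 0.06 h, with an expected range of 0.02 h to 0.17 h.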

Compound 3, half-life: 1.5 h
Compound 3: middle estimate off by 25-fold (1.40 log units), on the low side; the measured number lies above the stated range.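

Until now only the chain had been seen to matter in this assay, and this result shows that a place outside the chain counts as well. With the chain of compound 1 left as it is, a single fluoro on an aromatic carbon of the ring gives an at least 17-fold higher number from compound 1 to compound 3 (1.25 log units; beyond the scatter). So that chain does not on its own fix a short half-life: compound 3 keeps it and still gives 1.5 h, a measured number. The full size of the step stays unknown because its starting point, compound 1, is a limit: the limit of < 0.0834 h in this assay, at which 1 of the 3 values shown sits.

The compounds shown do not tell whether this gain is special to fluoro, or whether chloro, methoxy or a nitrile on the same ring carbon would bring a similar change, and they give no reason for the change itself. On these data alone, it also stays open whether fluoro at this place would matter on the chain of compound 2, or on a longer chain or one ending in an amine.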